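This account rests on a few compounds, and the source may have more. Where it says the series, first, only, none or still open, it means among the compounds named here.

In a functional assay for inhibition, with Homo sapiens as the target (a lower number here means a stronger inhibitor, a higher number a weaker inhibitor), compound 1 (`N=C(N)NCCC[C@@H]1NC(=O)N(CC(=O)N[C@@H](CC(=O)O)C(=O)N[C@@H](CO)C(=O)O)C1=O`) gives 10000 nM, compound 2 (`CC1(c2ccc(C(=N)N)cc2)NC(=O)N(CC(=O)NC(CC(=O)O)c2ccccc2)C1=O`) gives 200 nM, and compound 3 (`CC1(c2ccc(C(=N)N)cc2)NC(=O)N(CC(=O)NC(CC(=O)O)c2cccnc2)C1=O`) gives 100 nM. Compound 3 therefore has a far lower number than compound 1, but it cannot be told apart from compound 2. Compound 4 (`CC1(c2ccc(C(=N)N)cc2)NC(=O)N(CC(=O)NC(CC(=O)O)c2cccc3ccccc23)C1=O`) keeps the core of compound 3 and changes one group: naphthalen-1-yl in place of pyridin-3-yl on a saturated chain carbon bound to an amide-type nitrogen and a saturated chain carbon. This group sits on a saturated chain carbon bound to an amide-type nitrogen and a saturated chain carbon.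

Among the measured compounds shown here, the only measured step at this place, pyridin-3-yl in place of phenyl, is a 2.0-fold lower number from compound 2 to compound 3 (0.30 log units; within the scatter). Compound 1 differs from compound 3 in more than one place, so it offers little guidance. For the measured compounds named here, no measured compound carries naphthalen-1-yl, which leaves the outcome uncertain. A change beyond the scatter in this assay is therefore not expected, and the estimated step is a 1.5-fold higher number from compound 3 to compound 4 (0.18 log units; within the scatter). For compound 4, the expected value is 150 nM, with an estimated range from 40 nM to 600 nM.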

Compound 4, half-maximal inhibitory concentration: 300 nM
The estimate for compound 4 lay 2.0-fold (0.30 log units) below the measured number, and the stated range covers the measured number.
By their numbers in this assay, from the lowest: compounds 3, 2 and 4 (each within the scatter of the next, the first and the last beyond it); then compound 1.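

At this position, the larger naphthalen-1-yl group, with two aromatic rings of carbon only, gives in this assay a 3.0-fold higher number from compound 3 to compound 4 (0.48 log units; beyond the scatter), a modest weakening compared with pyridin-3-yl. Compared with phenyl, the same group gives a 1.5-fold higher number from compound 2 to compound 4 (0.18 log units; within the scatter), so compound 2 and compound 4 cannot be told apart, and this carbon tolerates the extra ring with at most a modest cost across these three compounds. Nothing available here explains why the number shifts.

From the compounds shown here alone, whether a group without an aromatic ring, such as cyclohexyl or a simple methyl, would keep the number close to those of compound 2 and compound 3 remains open. Going by these compounds, it is also open whether an amine added to the phenyl ring of compound 2 would move the number at all.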